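Series notes: from compound 3 to compound 4

This account rests on a few compounds, and the source may have more. Where it says the series, first, only, none or still open, it means among the compounds named here.

Measured in a functional assay on PANC-1 cells (Homo sapiens) for inhibition, read by MTT assay, with a stated time of 24 h, tested at 10 uM; a lower number here means less inhibition, a higher number more inhibition at the concentration tested (going by the name of the read-out):
compound 1 `CC(C)=CCC1Cc2c(OCc3ccccc3)cc(=O)n(CCCO)c2CC1(C)C` gives 11.1%
compound 2 `CC(C)=CCC/C(C)=C/COc1cc(=O)n(CCCO)c2c1CC(CC=C(C)C)C(C)(C)C2` gives 18.4%
compound 3 `CC(C)=CCC1Cc2c(OCCCNC(=O)c3cccs3)cc(=O)n(CCCO)c2CC1(C)C` gives 5.6%

Compound 3 stands lowest of the three numbers in this assay: a number 5.5 percentage points lower from compound 1 to compound 3 (within the scatter), and a number 12.8 percentage points lower from compound 2 to compound 3 (beyond the scatter). All three differ only in the group on the oxygen on the aromatic ring, and the steps between them are small: a number 7.3 percentage points higher from compound 1 to compound 2 (within the scatter).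

Compound 4 `CC(C)=CCC1Cc2c(OC(=O)Nc3ccc(F)cc3)cc(=O)n(CCCO)c2CC1(C)C` is not yet measured. The change from compound 3 is (4-fluorophenyl)carbamoyl in place of 3-(((thiophen-2-yl)carbonyl)amino)propyl on an oxygen on an aromatic ring. Among the measured compounds shown here, no measured step puts a carbamoyl on that oxygen; the steps in hand exchange chain and ring groups there and move the numbers little. On that basis compound 4 is expected to sit near its neighbours, with a number 6.4 percentage points higher from compound 3 to compound 4 (within the scatter) as the estimated step. The estimate for compound 4 in this assay is 12%, between 3% and 25%.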

Compound 4, a percentage reported as inhibition, at one concentration (the size of the read-out at that concentration, not a potency): 0%
For compound 4 the middle estimate is 12 percentage points above the measured one; the measured number lies below the stated range.
By their numbers in this assay, from the lowest: compounds 4, 3, 1 and 2 (each within the scatter of the next, the first and the last beyond it).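

In this assay, (4-fluorophenyl)carbamoyl on the oxygen on an aromatic ring stands apart from benzyl, a number 11.1 percentage points lower from compound 1 to compound 4 (beyond the scatter), and from 3,7-dimethylocta-2,6-dien-1-yl, a number 18.4 percentage points lower from compound 2 to compound 4 (beyond the scatter). Against 3-(((thiophen-2-yl)carbonyl)amino)propyl it cannot be separated, a number 5.6 percentage points lower from compound 3 to compound 4 (within the scatter), so a carbamoyl on this oxygen reads with compound 3 and apart from compound 1 and compound 2. No measurement in hand accounts for these steps.

The compounds shown leave open whether the number follows the carbamoyl link or the fluorine. A phenylcarbamoyl without fluorine and a methylcarbamoyl on the same oxygen would separate the two.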